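Selenium substituents on a shared core: notes toward compound 3

This account rests on a few compounds, and the source may have more. Where it says the series, first, only, none or still open, it means among the compounds named here.

Measured so far:
compound 1, `CCCCC[Se]c1nc([Se]CCCCC)c2cccnc2n1` — > 100000 nM
compound 2, `Nc1nc([SeH])nc2ncccc12` — 61500 nM

Going by the values given here, in a functional assay on CCRF-CEM cells (Homo sapiens) for cytotoxicity, read by MTT assay, with a stated time of 72 h (on this read-out lower numbers stand for stronger inhibition of growth and higher numbers for weaker inhibition of growth), compound 2 gives 61500 nM, the only actual number in the set. For compound 1 the result is a limit of the assay, > 100000 nM, and not a number; this is the limit of > 100000 nM in this assay, at which 1 of the 2 values shown sits. Among the compounds with values here, no pair of measured compounds differs in a single place, so no measured step is available to calibrate the series.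

Compound 3, `CCCCC[Se]c1nc(N)c2cccnc2n1`, has not been measured. It differs from compound 2 by pentyl in place of hydrogen on a selenium. Compound 3 thus keeps the amino group of compound 2 while carrying one of the two pentylseleno groups present in compound 1.

On this basis the step from compound 2 to compound 3 is expected to weaken growth inhibition somewhat, a 1.5-fold higher number from compound 2 to compound 3 (0.17 log units; within the scatter), because compound 1 with two such groups reaches only > 100000 nM. For compound 3 in this assay a value of 90000 nM is estimated, within the range 30000 nM to 250000 nM, with a real chance that the assay reports only a limit.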

Compound 3, concentration for total growth inhibition: 42800 nM
The estimate for compound 3 lay 2.1-fold (0.32 log units) above the measured number, within the range that was stated.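

In this assay, pentyl in place of hydrogen on a selenium gives a 1.4-fold lower number from compound 2 to compound 3 (0.16 log units; within the scatter), so this change does not separate the two compounds, and a pentyl group on a selenium whose other neighbour is an aromatic carbon is compatible with a read-out in the same range as the free selenium compound. The other step, one nitrogen atom in place of a group of 6 heavy atoms on an aromatic carbon, gives an at least 2.3-fold lower number from compound 1 to compound 3 (0.36 log units; beyond the scatter) in this assay, so the separation from compound 1 goes with the amino group against a pentylseleno group and not with the pentyl group the two compounds share. The size of that step is open-ended, since compound 1 gives a limit of the assay and not a number: the limit of > 100000 nM in this assay, at which 1 of the 3 values shown sits.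

The compounds shown leave open whether a shorter chain such as methyl, a longer chain such as octyl, or a benzyl group on the selenium would stay in this range. They also leave open whether a dimethylamino group in place of the amino group would keep compound 3 apart from compound 1.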